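The source may report more compounds than this note shows. Statements on the series, on what has been measured and on what is new or still open speak of the compounds shown alone.

Measured so far in a functional assay on MGC-803 cells (Homo sapiens) for inhibition, read by sulforhodamine B assay; a lower number here means a stronger inhibitor, a higher number a weaker inhibitor:

- compound 1, `O=C1C(Nc2cccc(Cl)c2)=CC(=O)c2c1nc1n2[C@H]2OC[C@@H](O)[C@H]2OC1` — 1530 nM
- compound 2, `O=C1C=C(Nc2ccccc2)C(=O)c2c1nc1n2[C@H]2OC[C@@H](O)[C@H]2OC1` — 1730 nM
- compound 3, `O=C1C=C(NC2CCCCC2)C(=O)c2c1nc1n2[C@H]2OC[C@@H](O)[C@H]2OC1` — only a limit, > 8000 nM

Compound 1 carries the lower of the two numbers, though its gap to compound 2 is within the usual scatter, so the two are not separated by this assay. Compound 3 sits at the limit of > 8000 nM in this assay, at which 1 of the 3 values shown sits, rather than at a number.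

Compound 4, `O=C1C(Nc2ccccc2F)=CC(=O)c2c1nc1n2[C@H]2OC[C@@H](O)[C@H]2OC1`, has not been measured. It differs from compound 1 by 2-fluorophenyl in place of 3-chlorophenyl on an amine nitrogen. For the measured compounds named here, the only measured step, an at least 4.6-fold higher number from compound 2 to compound 3 (0.66 log units; beyond the scatter), swaps an aromatic ring for a saturated one and bears only loosely on a change from one halogenated phenyl to another. Compounds 1 and 2, which differ by a chlorine on the phenyl, give values within the scatter of each other. Compound 4 is therefore expected to show a 1.1-fold higher number from compound 1 to compound 4 (0.05 log units; within the scatter), no step beyond the scatter. The estimate for compound 4 in this assay is 1700 nM, between 800 nM and 3600 nM.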

Compound 4, half-maximal inhibitory concentration: 2000 nM
Estimate against measurement, compound 4: 1.2-fold (0.07 log units) below, and the stated range covers the measured number.
By their numbers in this assay, from the lowest: compounds 1, 2 and 4 (each within the scatter of the next). At a limit, above all of these: compound 3.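

In this assay, replacing 3-chlorophenyl with 2-fluorophenyl on the amine nitrogen gives a 1.3-fold higher number from compound 1 to compound 4 (0.12 log units; within the scatter), so this assay does not separate these two halogenated phenyl groups. This is the first step shown that keeps an aromatic ring at this place while changing both the halogen and where it stands on the ring, and that double change leaves no difference beyond the scatter. Compound 3, with cyclohexyl on its amine nitrogen, gives only a limit, not a number: the limit of > 8000 nM in this assay, at which 1 of the 4 values shown sits.

On these data alone, it remains open whether a plain phenyl group in the same place as in compound 1 and compound 4 would fall with them, which would show whether either halogen matters here. Also open, as far as these compounds go, is how a benzyl group, or a phenyl ring carrying a methoxy group or a carboxylic acid, would read in this assay.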